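A few compounds are considered here, and "the series" means these few. Any claim that something is new, unique, unknown or untested is made for them only; others in the source may bear on it.

Compounds measured in an assay on CHO cells for displacement of a labelled ligand from adenosine receptor A1 (Homo sapiens), read by scintillation counting, with a stated time of 120 min, tested at 10 uM; a higher number here means more inhibition at the concentration tested (going by the name of the read-out), a lower number less inhibition:
- compound 1 `Nc1scc(CN2CCN(c3cccnc3)CC2)c1C(=O)c1ccc(Cl)cc1` — 0%
- compound 2 `Nc1scc(CN2CCN(c3cc(F)cc(F)c3)CC2)c1C(=O)c1ccc(Cl)cc1` — 0%
- compound 3 `Nc1scc(CN2CCN(c3c(F)cccc3F)CC2)c1C(=O)c1ccc(Cl)cc1` — 1%

Compound 3 stands highest of the three numbers, but only nominally: the step of a number 1 percentage points higher from compound 1 to compound 3 (within the scatter) and the step of a number 1 percentage points higher from compound 2 to compound 3 (within the scatter) are both within the scatter, as is no change at the digits printed from compound 1 to compound 2 (within the scatter). Across the three compounds the shared core is unchanged, and only the aryl group on the ring nitrogen of the piperazine-type ring is varied, with no effect beyond the scatter in any case.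

Compound 4 `Nc1scc(CN2CCN(c3ccccc3Cl)CC2)c1C(=O)c1ccc(Cl)cc1` continues this series of aryl exchanges. Its change is 2-chlorophenyl in place of 2,6-difluorophenyl on an amine nitrogen in a ring. All three measured steps bear on it, since each swaps one aryl group for another in the same place, and each was within the scatter. On that basis the step of a number 1 percentage points higher from compound 3 to compound 4 (within the scatter) is expected to be none beyond the scatter. Compound 4 is therefore estimated at 2%, with a range from -5% to 12%.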

Compound 4, a percentage reported as inhibition, at one concentration (the size of the read-out at that concentration, not a potency): 2%
Estimate against measurement, compound 4: no gap at the digits printed; the range from low to high includes it.
By their numbers in this assay, from the lowest: compounds 1, 2, 3 and 4 (each within the scatter of the next).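

In this assay, the exchange to 2-chlorophenyl on the amine nitrogen in a ring gives a number 1 percentage points higher from compound 3 to compound 4 (within the scatter), and the comparisons with the other two aryl groups give a number 2 percentage points higher from compound 2 to compound 4 (within the scatter) and a number 2 percentage points higher from compound 1 to compound 4 (within the scatter). Among the compounds shown here, a chlorine-bearing phenyl group thus joins the two difluorophenyl groups and pyridin-3-yl at this position, and no step among the four compounds lies beyond the scatter. No measurement is available that would account for this result.

From the compounds shown here alone, all four groups at this position are six-membered aromatic rings, so it remains open whether a benzyl group, an acyl group or a longer alkyl chain on this nitrogen would give a different number. The compounds also leave open whether a change elsewhere on the shared core, such as to the amine or the carbonyl, would alter the read-out.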